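Aryl variation on the shared core: toward compound 4

The source may report more compounds than this note shows. Statements on the series, on what has been measured and on what is new or still open speak of the compounds shown alone.

Measured so far:
compound 1 `COc1cc(-c2ccc3ncn(-c4cc(OC)c(OC)c(OC)c4)c3c2)cc(OC)c1OC`: > 10000 nM
compound 2 `COc1cc(-n2cnc3ccc(-c4cccc(C)c4C)cc32)cc(OC)c1OC`: 9250 nM
compound 3 `COc1cc(-n2cnc3ccc(-c4ccccc4Cl)cc32)cc(OC)c1OC`: > 10000 nM

For the measured compounds named here, in a functional assay on A549 cells (Homo sapiens) for antiproliferative activity, read by MTT assay, with a stated time of 72 h (on this read-out lower numbers stand for stronger inhibition and higher numbers for weaker inhibition), compound 2 gives 9250 nM and is the only member of the set with a number rather than a limit. Compound 1 sits at a limit of the assay. Compound 3 also sits at a limit of the assay. Both of those share (the limit of > 10000 nM in this assay, at which 2 of the 3 values shown sit), so compound 2 is known only to lie just short of that limit.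

Compound 4 `COc1cc(-n2cnc3ccc(-c4ccc(C)cc4F)cc32)cc(OC)c1OC` differs from compound 2 in one place: 2-fluoro-4-methylphenyl in place of 2,3-dimethylphenyl on an aromatic carbon. Going by the values given here, the one measured step on the same aromatic carbon, an at least 1.0-fold higher number from compound 2 to compound 3 (0.03 log units; that floor lies within the scatter), lies within the scatter and ends at a limit. Among the compounds with values here, that step bears on the change to compound 4, since the incoming group again replaces 2,3-dimethylphenyl with a differently substituted phenyl; no further step is available.

Compound 4 is therefore expected near the limit, with an estimate of 10000 nM and a range of 5000 nM to 20000 nM. The expected step of a 1.1-fold higher number from compound 2 to compound 4 (0.03 log units; within the scatter) stays within the scatter, with a fair chance that only a limit is reported.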

Compound 4, half-maximal inhibitory concentration: > 10000 nM
Compound 4 gave a limit, no number (the forecaster's own chance of this, stated with the estimate: 50%); the middle value lies on the limit itself.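

Replacing 2,3-dimethylphenyl with 2-fluoro-4-methylphenyl on this aromatic carbon gives, in this assay, an at least 1.0-fold higher number from compound 2 to compound 4 (0.03 log units; that floor lies within the scatter). After the 2-chlorophenyl of compound 3, this is a second change of phenyl substitution at this position that yields no measured gain, here with a fluorine-bearing ring. The step between compound 3 and compound 4 cannot be read, as both values are limits, and the series now rests mostly on that one limit: the limit of > 10000 nM in this assay, at which 3 of the 4 values shown sit.

Going by these compounds, how far compound 3 and compound 4 lie past the limit stays unknown, so these phenyl groups cannot be ranked against each other. Also open, on these data alone, is whether a phenyl carrying an amine or a carboxylic acid at this position would give a clear number well short of the limit.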